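Diethylamino to hydroxy on the carbonyl of compound 2

A few compounds are considered here, and "the series" means these few. Any claim that something is new, unique, unknown or untested is made for them only; others in the source may bear on it.

In a functional assay on A-427 cells (Homo sapiens) for cytotoxicity, read by colorimetric assay and MTT assay (a higher number here means a weaker inhibitor, a lower number a stronger inhibitor), compound 1 (`COc1ccc(-c2cc3cccc(OC)c3nc2O)cc1`) gives 10000 nM. Compound 2 (`CCN(CC)C(=O)Cn1c(=O)c(-c2ccc(OC)cc2)cc2c(OC)cc(OC)cc21`) gives 10000 nM, which stands level with compound 1 within the scatter. Compound 3 (`COc1ccc(-c2cc3c(OC)cc(OC)cc3n(CC(=O)O)c2=O)cc1`) has not yet been measured in this assay. It carries hydroxy in place of diethylamino on a carbonyl carbon. Going by the values given here, no measured pair shows this change, so the expectation rests only on the two values so far. No shift beyond the scatter is expected in this assay, and the expected step is no change at the digits printed from compound 2 to compound 3 (within the scatter). The estimated value for compound 3 is 10000 nM, with an expected range of 4000 nM to 20000 nM.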

Compound 3, half-maximal inhibitory concentration: 10000 nM
Compound 3: the middle estimate sits on the measured number at the digits printed, and the stated range covers the measured number.
By their numbers in this assay, from the lowest: compounds 1, 2 and 3 (each within the scatter of the next).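

Going by these compounds alone, exchanging diethylamino for hydroxy on a carbonyl carbon whose other neighbour is a saturated chain carbon gives the first measured step at this position: in this assay it is no change at the digits printed from compound 2 to compound 3 (within the scatter) and so the diethylcarbamoyl and carboxy forms cannot be told apart here. No measurement on hand offers an explanation for this result. As far as these compounds go, whether a methyl ester or a primary amide at this carbonyl carbon, or a longer chain in place of the carboxymethyl, would move the value beyond the scatter remains open.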